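This account rests on a few compounds, and the source may have more. Where it says the series, first, only, none or still open, it means among the compounds named here.

Measured so far in an assay on cells for inhibition of MAP kinase-interacting serine/threonine-protein kinase 1 (Homo sapiens), read by mobility shift assay, with stated times of 10 min and 60 min, in the presence of a further agent that is not named here; a lower number here means a stronger inhibitor, a higher number a weaker inhibitor: compound 1 `CC(C)Oc1cc(-c2cncc(-c3cnn(C(C)C)c3)c2)ccc1C(N)=O` gives 85 nM; compound 2 `NC(=O)c1ccc(-c2cccnc2)cc1OC1CCNC1` gives 1900 nM; compound 3 `Cc1c(-c2cncc(-c3ccc(C(N)=O)c(OC(C)C)c3)c2)cnn1C` gives 60 nM.

Compound 2 has the highest number of the three, and its distance from both compound 1 and compound 3 lies beyond the scatter. Compound 4 `NC(=O)c1ccc(-c2cccnc2)cc1` differs from compound 2 at one place: hydrogen in place of (pyrrolidin-3-yl)oxy on an aromatic carbon. Among the measured compounds shown here, the only measured step, a 1.4-fold lower number from compound 1 to compound 3 (0.15 log units; within the scatter), exchanges one pyrazole for another on a different part of the shared core and says nothing about taking a group off the ring that bears the carbamoyl group. Compounds 1 and 3 carry a different group at this place and are far stronger than compound 2, yet they differ elsewhere too, so no direct guide exists. Compound 4 is therefore expected to be somewhat weaker, about a 2.6-fold higher number from compound 2 to compound 4 (0.42 log units; beyond the scatter). The estimate for compound 4 is 5000 nM, ranging from 1500 nM to 20000 nM.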

Compound 4, half-maximal inhibitory concentration: 8800 nM
The estimate for compound 4 lay 1.8-fold (0.25 log units) below the measured number, and the stated range covers the measured number.
By their numbers in this assay, from the lowest: compounds 3 and 1 (each within the scatter of the next); then compound 2; then compound 4.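

Among the compounds shown here, replacing (pyrrolidin-3-yl)oxy with hydrogen on this aromatic carbon, ortho to the carbamoyl group, gives the first direct reading at this position (a 4.6-fold higher number from compound 2 to compound 4 (0.67 log units; beyond the scatter)). The step is modest but lies beyond the scatter, so on this core the group adds some inhibition, though far from all of it. No measurement at hand explains this step.

Which part of the group counts, the oxygen or the ring with its nitrogen, stays open. A methoxy group or a 2-aminoethoxy chain on this same carbon would separate the two.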